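Oxazolyl for methylpyrazolyl on the fused core of compound 1

This account rests on a few compounds, and the source may have more. Where it says the series, first, only, none or still open, it means among the compounds named here.

Compound 1 `Cn1ccc(-c2cccc3c2CCC3c2ncc[nH]2)n1` carries a 1-methyl-1H-pyrazol-3-yl group on its fused core. In a functional assay on CHO cells for agonist activity at Alpha-1A adrenergic receptor (Homo sapiens), read by FLIPR and calcium flux (on this read-out lower numbers stand for an effect already at smaller amounts and higher numbers for an effect only at larger amounts of compound), compound 1 reaches only a limit of the assay, > 1300 nM. The other members are of a different build. Compound 2 `CCS(=O)(=O)Nc1cccc(Cc2c[nH]cn2)c1` is an open, non-fused analogue and in this assay compound 2 gives 9 nM. Compound 3 `CS(=O)(=O)Nc1cccc2c1CCCC2c1ncc[nH]1` has a six-membered saturated ring in its core and in this assay compound 3 gives 2150 nM; 142 nM; 234 nM (3 entries); the spread among these entries, (the several entries of compound 3 in this assay, 2150 nM; 142 nM; 234 nM (3 entries)), shows how wide repeat values can run for this kind of compound. The limit of compound 1 in this assay is a limit of the assay, and one of the entries of compound 3 sits close to it, (the limit of > 1300 nM in this assay, at which 1 of the 3 values shown sits).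

Compound 4 `c1cc(-c2ncco2)c2c(c1)C(c1ncc[nH]1)CC2` differs from compound 1 in one place: 1,3-oxazol-2-yl in place of 1-methyl-1H-pyrazol-3-yl on an aromatic carbon. Among the compounds with values here, no step between measured compounds covers this change, so expectations rest on compound 1 alone. With compound 1 known only as a limit, the step from compound 1 to compound 4 in this assay is expected to be small, a step that the limit leaves unreadable from compound 1 to compound 4, with no clear direction beyond the scatter, and a further limit is a real possibility. Compound 4 is therefore estimated at 1500 nM in this assay, with a range from 300 nM to 6000 nM.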

Compound 4, half-maximal effective concentration: 170 nM
Estimate against measurement, compound 4: 8.8-fold (0.95 log units) above; measured number below the stated range.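

Read in this assay, the aromatic carbon of the shared core responds to the choice of five-membered ring: the change of 1-methyl-1H-pyrazol-3-yl to 1,3-oxazol-2-yl gives an at least 7.6-fold lower number from compound 1 to compound 4 (0.88 log units; beyond the scatter). Both groups are five-membered aromatic rings with the same counts of hydrogen-bond donors and acceptors, so the response at this position cannot be read from those counts alone, although the heavy atoms of the two groups do differ. For compound 1, > 1300 nM is a limit of the assay and not a number, and the step is therefore known from one side only.

As far as these compounds go, whether the step keeps its size on repeat stays open for compound 4, which has a single entry, and repeat values for this kind of compound can run wide: the several entries of compound 3 in this assay, 2150 nM; 142 nM; 234 nM (3 entries) Also open is how an amine, a carboxylic acid or a longer chain in place of 1,3-oxazol-2-yl on this aromatic carbon would read in this assay, and which atoms of 1,3-oxazol-2-yl carry the step.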